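The source may hold more compounds than are shown below. What is called first, only, known or untested is meant among the compounds shown, and "the series" means these compounds.

Measured so far:
- compound 1, `COc1ccc(Nc2nc(N[C@H]3CC[C@H](N)CC3)nc3c2ncn3CCC(C)C)c(OC)c1`: 6300 nM in a functional assay on MCF7 cells (Homo sapiens) for inhibition, read by fluorescence, with a stated time of 72 h; a higher number here means a weaker inhibitor of growth, a lower number a stronger inhibitor of growth
- compound 2, `N[C@H]1CC[C@H](Nc2nc(Nc3cccc(Cl)c3)c3ncn(Cc4ccccc4)c3n2)CC1`: 3600 nM in this assay

Compound 1 gives the highest of the two numbers shown, and its nearest neighbour is compound 2, whose number is lower by an amount that lies within the scatter of repeated measurements; the two compounds therefore cannot be told apart on these data, and no ordering between them is claimed. The two compounds also differ in more than one place, so no single structural step can be read from their values.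

Compound 3, `CC(C)CCn1cnc2c(Nc3ccc(O)cc3)nc(N[C@H]3CC[C@H](N)CC3)nc21`, has not yet been measured in this assay. It is related to compound 1 by one change only:

4-hydroxyphenyl in place of 2,4-dimethoxyphenyl on a nitrogen on an aromatic ring

With no measured step of this kind in the set, the expectation rests on the change itself and on the value of compound 1. A step of modest size is expected, toward a lower number, close to the edge of the usual scatter: a 2.5-fold lower number from compound 1 to compound 3 (0.40 log units; beyond the scatter). On that basis compound 3 is estimated at 2500 nM, with a range from 600 nM to 10000 nM.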

Compound 3, concentration for 50% growth inhibition: 3100 nM
The estimate for compound 3 lay 1.2-fold (0.09 log units) below the measured number; the range from low to high includes it.
By their numbers in this assay, from the lowest: compounds 3, 2 and 1 (each within the scatter of the next, the first and the last beyond it).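

In this assay, the group on a nitrogen on an aromatic ring now has its first readable step: 4-hydroxyphenyl in place of 2,4-dimethoxyphenyl gives a 2.0-fold lower number from compound 1 to compound 3 (0.31 log units; beyond the scatter) and this step is modest. The group here can therefore be changed with a measurable effect on growth inhibition, and the smaller group, with fewer heavy atoms and a hydrogen-bond donor where the old group had none, does not give a higher number. This single step bundles several differences, however: one methoxy group is gone and the other has become a hydroxyl, so the step cannot show which of these differences matters.

The compounds shown leave open what a plain phenyl, a 4-methoxyphenyl or a 4-aminophenyl on this nitrogen would give, and such groups could help separate the loss of a methoxy group from the gain of a hydroxyl. Nothing else given here bears on why the number moved.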